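Swapping the aryl group on the oxadiazole of compound 1

The compounds below may be only part of what the source reports. "The series", "measured", "known", "first", "only" and "open" are said of these compounds alone.

Measured so far:
compound 1 `Cc1nc2cc(OC[C@H](O)CN3CCN(Cc4noc(-c5ccc(Cl)cc5)n4)CC3)ccc2s1`: 2270 nM
compound 2 `Cc1nc2cc(OC[C@H](O)CN3CCN(Cc4nnc(-c5ccc(Cl)cc5)o4)CC3)ccc2s1`: 8500 nM

Of the compounds shown here, two have been tested in a functional assay on mitochondria from heart for inhibition of peroxisomal acyl-coenzyme A oxidase 1 (Rattus norvegicus); on this read-out lower numbers stand for stronger inhibition and higher numbers for weaker inhibition. In this assay compound 1 gives 2270 nM, and compound 2 gives 8500 nM. Of these two numbers compound 1 stands lowest, and its gap to compound 2 lies beyond the scatter of repeated measurements, so compound 1 is the stronger inhibitor of the pair.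

Compound 3 `Cc1cccc(-c2nc(CN3CCN(C[C@@H](O)COc4ccc5sc(C)nc5c4)CC3)no2)c1` has not yet been measured. It differs from compound 1 in a single place: 3-methylphenyl in place of 4-chlorophenyl on an aromatic carbon. Within the data shown here, no measured pair shows this particular exchange, so its effect cannot be read from the data; the two compounds measured so far differ in another part of the molecule.

Compound 3 is therefore expected to give about 4000 nM, with a likely range from 1500 nM to 11000 nM. That estimate corresponds to an expected step of a 1.8-fold higher number from compound 1 to compound 3 (0.25 log units; within the scatter), a shift toward weaker inhibition that may or may not rise above the scatter.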

Compound 3, half-maximal inhibitory concentration: 6500 nM
Estimate against measurement, compound 3: 1.6-fold (0.21 log units) below; the range from low to high includes it.
By their numbers in this assay, from the lowest: compound 1; then compounds 3 and 2 (each within the scatter of the next).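

The aryl group on the oxadiazole matters in this assay: exchanging 4-chlorophenyl for 3-methylphenyl gives a 2.9-fold higher number from compound 1 to compound 3 (0.46 log units; beyond the scatter), a shift toward weaker inhibition. The two groups match in their count of seven heavy atoms, each has one six-membered carbon ring, and neither has hydrogen-bond donors, hydrogen-bond acceptors or a net charge, so a change that leaves these counts the same can still move the value beyond the scatter. The data shown offer no measurement that explains this step.

This single exchange alters both the substituent and its place on the phenyl ring, so the contribution of each remains unresolved. A 4-methylphenyl or 3-chlorophenyl group would change only one of these at a time and could separate the two contributions.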